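Dropping the chloro: an allyloxy-benzoyl-pyridine pair in HeLa cells

The source may hold more compounds than are shown below. What is called first, only, known or untested is meant among the compounds shown, and "the series" means these compounds.

Measured compounds:
- compound 1, `C=CCOc1cc(Br)ccc1C(=O)c1cccnc1`: > 100000 nM
- compound 2, `C=CCOc1c(Cl)cccc1C(=O)c1cccnc1`: 100000 nM

Of the compounds shown here, two have been tested in a functional assay on HeLa cells (Homo sapiens) for cytotoxicity, read by sulforhodamine B assay, with a stated time of 48 h; on this read-out higher numbers stand for weaker inhibition and lower numbers for stronger inhibition. For compound 1 the result is a limit of the assay rather than a number, > 100000 nM. For the measured compounds named here, compound 2 gives 100000 nM in this assay, the only actual number in the set. One of the two results, that of compound 1, sits at the limit, as shown by the limit of > 100000 nM in this assay, at which 1 of the 2 values shown sits. Going by the values given here, compound 2 therefore stands alone as the sole measured value, with nothing to compare it against.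

Compound 3, `C=CCOc1ccccc1C(=O)c1cccnc1`, has not been measured. It differs from compound 2 by hydrogen in place of chloro on an aromatic carbon. Among the compounds with values here, no measured pair in this set shows what such a change does, so the expected step from compound 2 to compound 3 in this assay is taken as none beyond the usual scatter.

Compound 3 is therefore expected to give about 100000 nM in this assay, within the range 40000 nM to 250000 nM, which means an expected step of no change at the digits printed from compound 2 to compound 3 (within the scatter).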

Compound 3, half-maximal inhibitory concentration: > 100000 nM
Compound 3: only a limit was reported (the forecaster's own chance of this, stated with the estimate: 55%); the middle value sits exactly at the limit.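

In this assay, hydrogen in place of chloro on the aromatic carbon ortho to the allyloxy group gives a number no lower from compound 2 to compound 3 (the limit leaves the size open), so removing the chloro brings no sign of stronger inhibition. For compound 3 the result is a limit of the assay rather than a number, > 100000 nM. The step between compound 1 and compound 3 cannot be read, and the set now offers little room to tell these compounds apart: the limit of > 100000 nM in this assay, at which 2 of the 3 values shown sit.

On these data alone, how much the chloro contributes to the result for compound 2 stays open, as the true number for compound 3 could lie anywhere past the limit. Also open, as far as these compounds go, is whether an amine or a carboxylic acid on this aromatic carbon, or a longer chain in place of the allyloxy group, would give a clearly lower number on the same core.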